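A few compounds are considered here, and "the series" means these few. Any claim that something is new, unique, unknown or untested is made for them only; others in the source may bear on it.

In a functional assay on FM3A cells (Mus musculus) for antiproliferative activity (a lower number here means a stronger inhibitor, a higher number a weaker inhibitor), three compounds sharing one core have been measured. Compound 1 (`COc1cc(C(=O)c2sc(-c3cccc([N+](=O)[O-])c3)cc2N)cc(OC)c1OC`) gives 17 nM and compound 2 (`COc1cc(C(=O)c2sc(-c3ccccc3Cl)cc2N)cc(OC)c1OC`) gives 34 nM while compound 3 (`COc1cccc(-c2cc(N)c(C(=O)c3cc(OC)c(OC)c(OC)c3)s2)c1`) gives 36 nM on the same scale. Compound 3 sits at the upper end of these numbers, but only compound 1 stands apart from it beyond the scatter.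

Compound 4 (`CCOc1ccc(-c2cc(N)c(C(=O)c3cc(OC)c(OC)c(OC)c3)s2)cc1`) keeps the core and changes the aryl group on the aromatic carbon next to the ring sulfur, with 4-ethoxyphenyl in place of 3-methoxyphenyl on an aromatic carbon is the counted difference.

For the measured compounds named here, no measured pair isolates this exchange, so the evidence is indirect. Three steps involve aryl changes at this same place. The first is a 2.0-fold higher number from compound 1 to compound 2 (0.30 log units; within the scatter) and the second is a 1.1-fold higher number from compound 2 to compound 3 (0.02 log units; within the scatter) while the third and largest is a 2.1-fold higher number from compound 1 to compound 3 (0.33 log units; beyond the scatter) and is only modest. On these three steps, no change beyond the scatter is expected in this assay, although the data cannot rule one out in either direction. The expected size of the change is a 1.2-fold lower number from compound 3 to compound 4 (0.08 log units; within the scatter) as estimated from these steps. Compound 4 is estimated at 30 nM (expected range 10 nM to 90 nM).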

Compound 4, half-maximal inhibitory concentration: 510 nM
Estimate against measurement, compound 4: 17-fold (1.23 log units) below, outside the stated range (above it).
By their numbers in this assay, from the lowest: compounds 1, 2 and 3 (each within the scatter of the next, the first and the last beyond it); then compound 4.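

In this assay the three earlier aryl groups on the aromatic carbon next to the ring sulfur gave no hint of how much this place can matter, but the 4-ethoxyphenyl group shows it, with a 14-fold higher number from compound 3 to compound 4 (1.15 log units; beyond the scatter) and a 15-fold higher number from compound 2 to compound 4 (1.18 log units; beyond the scatter) and, against the lowest number of the series, a 30-fold higher number from compound 1 to compound 4 (1.48 log units; beyond the scatter) as the widest gap. The tolerance seen among 3-nitrophenyl, 2-chlorophenyl and 3-methoxyphenyl therefore does not extend to every substituted phenyl group here, and compound 4 is the weakest inhibitor of the four. Nothing available here accounts for this sharp rise in the number.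

The exchange from 3-methoxyphenyl to 4-ethoxyphenyl alters both the place of the ether on the phenyl ring and the length of its chain, and the compounds shown cannot separate the two, which 4-methoxyphenyl or 3-ethoxyphenyl at this place could do. They also leave open whether a longer chain such as 4-propoxyphenyl would raise the number further, and how a group such as 4-aminophenyl or 4-carboxyphenyl would behave at the same place.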